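This account rests on a few compounds, and the source may have more. Where it says the series, first, only, none or still open, it means among the compounds named here.

Compound 1 `N#C/C(=C\c1c(F)c(F)c(F)c(F)c1F)C(=O)c1ccc[nH]1` and compound 2 `COc1ccc(CNC(=O)/C(C#N)=C/c2ccc3ccccc3c2)cc1` were both tested in a functional assay on DU-145 cells (Homo sapiens) for inhibition, read by MTT assay, with a stated time of 72 h; a higher number here means a weaker inhibitor of growth, a lower number a stronger inhibitor of growth. Compound 1 reached only a limit of the assay in this assay, > 100000 nM. Compound 2 gave a measured number in this assay, 80000 nM. For the measured compounds named here, this is the only actual number among the values shown; the other value, that of compound 1, is a limit, as summarised in the limit of > 100000 nM in this assay, at which 1 of the 2 values shown sits. Compound 3 `N#C/C(=C\c1ccc2ccccc2c1)C(=O)NCc1ccc(Cl)c(Cl)c1` has not yet been measured in this assay. It differs from compound 2 in one place: 3,4-dichlorophenyl in place of 4-methoxyphenyl on a saturated chain carbon bound to an amide-type nitrogen. Going by the values given here, no pair of measured compounds shares this change, and there is no measured step to lean on. With only the value of compound 2 as a starting point, the step from compound 2 to compound 3 is expected to be small, not beyond the scatter, in either direction, a 1.3-fold lower number from compound 2 to compound 3 (0.12 log units; within the scatter). Compound 3 is accordingly expected to give about 60000 nM in this assay, somewhere between 20000 nM and 150000 nM.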

Compound 3, concentration for 50% growth inhibition: 77000 nM
Estimate against measurement, compound 3: 1.3-fold (0.11 log units) below, and the stated range covers the measured number.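

In this assay, putting 3,4-dichlorophenyl in place of 4-methoxyphenyl on a saturated chain carbon bound to an amide-type nitrogen gives a 1.0-fold lower number from compound 2 to compound 3 (0.02 log units; within the scatter). For the compounds shown here, this is the first measured step at this position, and it shows that the two rings can be exchanged here without a readable difference, even though one brings a hydrogen-bond acceptor and the other brings two chlorine atoms and no acceptor. Compound 1 stays a limit rather than a number, which is a reminder that this series sits at the weak end of what the assay can report: the limit of > 100000 nM in this assay, at which 1 of the 3 values shown sits.

From the compounds shown here alone, a single swap between two substituted phenyl rings cannot show whether this position is insensitive in general, so it remains open whether a ring carrying a carboxylic acid or an amine, or a longer chain in place of the ring, would move the number beyond the scatter. Going by these compounds, it is also open whether the same exchange would stay this flat on a core that gives a much lower number in this assay.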